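Swapping Isopropyl for Methyl on the Ring Nitrogen

The compounds below may be only part of what the source reports. "The series", "measured", "known", "first", "only" and "open" are said of these compounds alone.

Measured so far in a functional assay on MDA-MB-231 cells (Homo sapiens) for cytotoxicity, read by MTT assay, with a stated time of 48 h; on this read-out higher numbers stand for weaker inhibition and lower numbers for stronger inhibition:
compound 2 `CC(C)n1c(/C=C2/C(=O)Nc3ccc(Cl)cc32)nc2ccccc21`: 25100 nM
compound 3 `CC(C)n1c(/C=C2/C(=O)Nc3ccc(Br)cc32)nc2ccccc21`: 3260 nM
compound 1 `Cn1c(/C=C2/C(=O)Nc3ccc([N+](=O)[O-])cc32)nc2ccccc21`: "not determined" (no result reported)

Among the measured compounds shown here, compound 2 gives the highest of the two numbers, with a 7.7-fold lower number from compound 2 to compound 3 (0.89 log units; beyond the scatter) as the only measured step. Compound 4 `Cn1c(/C=C2/C(=O)Nc3ccc(Cl)cc32)nc2ccccc21` differs from compound 2 by methyl in place of isopropyl on an aromatic nitrogen. For the measured compounds named here, no measured step touches this change: compound 1 carries the methyl but has no number, and the single step between compound 2 and compound 3 concerns the halogen, not the ring nitrogen. With nothing to build on, no shift beyond the scatter is expected, so for compound 4 the estimate is 25000 nM, within 8000 nM to 80000 nM, which means an expected step of a 1.0-fold lower number from compound 2 to compound 4 (0.00 log units; within the scatter).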

Compound 4, half-maximal inhibitory concentration: 37600 nM
Estimate against measurement, compound 4: 1.5-fold (0.18 log units) below, within the range that was stated.
By their numbers in this assay, from the lowest: compound 3; then compounds 2 and 4 (each within the scatter of the next).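

In this assay, methyl in place of isopropyl on the aromatic nitrogen gives a 1.5-fold higher number from compound 2 to compound 4 (0.18 log units; within the scatter). With chloro on the shared core, then, this position shows no change that can be told from the scatter when the smaller group replaces the larger one. No measurement at hand offers an explanation for this result.

From the compounds shown here alone, whether methyl and isopropyl also match with bromo in place of chloro remains open. So does the outcome of putting a longer chain, or a chain ending in an amine, on this nitrogen.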